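Selenocyanate chain variation at the aromatic carbon

The compounds below may be only part of what the source reports. "The series", "measured", "known", "first", "only" and "open" are said of these compounds alone.

In a functional assay on A549 cells (Homo sapiens) for inhibition, read by MTT assay, with a stated time of 48 h (on this read-out lower numbers stand for stronger inhibition and higher numbers for weaker inhibition), compound 2 `COc1ccc(N(C)c2nc(C)nc3ccccc23)cc1C[Se]C#N` gives 98 nM, the lowest of the two numbers in hand, while compound 1 `COc1ccc(N(C)c2nc(C)nc3ccccc23)cc1C(=O)OCC[Se]C#N` gives 353 nM. Among the compounds with values here, the only measured step, a 3.6-fold lower number from compound 1 to compound 2 (0.56 log units; beyond the scatter), came with the smaller group in place of the larger one. Compound 3 `COc1ccc(N(C)c2nc(C)nc3ccccc23)cc1OCCCC[Se]C#N` differs from compound 2 as follows: a group of 8 heavy atoms (5 carbon, 1 nitrogen, 1 oxygen, 1 selenium; no ring) in place of a group of 4 heavy atoms (2 carbon, 1 nitrogen, 1 selenium; no ring), on an aromatic carbon. Within the data shown here, since this change runs opposite to the measured step, the number for compound 3 is expected to rise, although the entering group is not the one present in compound 1. Compound 3 is therefore estimated at 220 nM, between 80 nM and 600 nM, an expected 2.2-fold higher number from compound 2 to compound 3 (0.35 log units; beyond the scatter).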

Compound 3, half-maximal inhibitory concentration: 1200 nM
The estimate for compound 3 lay 5.5-fold (0.74 log units) below the measured number; measured number outside the range, above it.
By their numbers in this assay, from the lowest: compound 2; then compound 1; then compound 3.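

Group size alone does not set the number at this aromatic carbon: two groups of 8 heavy atoms differ, with a 3.4-fold higher number from compound 1 to compound 3 (0.53 log units; beyond the scatter). Within the data shown here, the largest step so far also appears here, with the group of 8 heavy atoms entering in place of the group of 4 heavy atoms, giving a 12-fold higher number from compound 2 to compound 3 (1.09 log units; beyond the scatter). Nothing available explains either step.

From the compounds shown here alone, whether chain length or the oxygen attached to the aromatic carbon drives these steps remains open; a shorter oxygen-linked selenocyanate chain would separate the two. Going by these compounds, whether selenium is needed also remains open, and a thiocyanate on the same chain would test it.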